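Ethyl to tert-butyl on a bromo-free pendant ring

This account rests on a few compounds, and the source may have more. Where it says the series, first, only, none or still open, it means among the compounds named here.

Measured compounds:
compound 1 `COC(=O)c1ccc2c(c1)S(=O)(=O)N=S2c1ccc(Br)cc1` 4100 nM
compound 2 `NS(=O)(=O)c1ccc2c(c1)S(=O)(=O)N=S2c1ccc(Br)cc1` 91100 nM
compound 3 `CCc1ccc(S2=NS(=O)(=O)c3cc([N+](=O)[O-])ccc32)cc1` 180 nM

Of the compounds shown here, three sharing one core have been tested in an assay on isolated protein for inhibition of Polyunsaturated fatty acid 5-lipoxygenase (Homo sapiens), read by immunoassay, with a stated time of 15 min; a lower number here means a stronger inhibitor, a higher number a weaker inhibitor. Compound 3 gives the lowest number of the three, 180 nM, and its gaps to the other two lie beyond the scatter, so it is the strongest inhibitor so far. Compound 1 gives 4100 nM and compound 2 gives 91100 nM.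

Among the compounds with values here, only one step between measured compounds changes a single place: a 22-fold higher number from compound 1 to compound 2 (1.35 log units; beyond the scatter). That change sits on the core, not on the pendant ring.

Compound 4 `CC(C)(C)c1ccc(S2=NS(=O)(=O)c3cc([N+](=O)[O-])ccc32)cc1` differs from compound 3 by tert-butyl in place of ethyl on an aromatic carbon. Within the data shown here, no measured step touches this position, and the one known step concerns a different part of the molecule, so it gives no direct guidance. With nothing to point either way, the expectation for compound 4 in this assay is a step that stays within the usual scatter, a 1.2-fold lower number from compound 3 to compound 4 (0.08 log units; within the scatter).

Compound 4 is therefore estimated at 150 nM, with a range from 50 nM to 500 nM.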

Compound 4, half-maximal inhibitory concentration: 300 nM
For compound 4 the middle estimate is 2.0-fold (0.30 log units) below the measured one; measured number inside the range.
By their numbers in this assay, from the lowest: compounds 3 and 4 (each within the scatter of the next); then compound 1; then compound 2.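

Within the data shown here, the only earlier step changed the core; this is the first reading at an aromatic carbon of a six-membered aromatic ring of carbon only, para to a large group. In this assay the change from ethyl, with 2 heavy atoms, to tert-butyl, with 4 heavy atoms, gives a 1.7-fold higher number from compound 3 to compound 4 (0.22 log units; within the scatter), which means that this measurement does not tell the two compounds apart, and adding these heavy atoms at this place produces no step beyond the scatter. Nothing measured here accounts for this result.

Ethyl and tert-butyl are both made of carbon and hydrogen alone, and these compounds do not show how an amine, a carboxylic acid or a longer chain such as hexyl would read on this same carbon. From the compounds shown here alone, it also remains open whether tert-butyl and ethyl would read alike on a core carrying methoxycarbonyl or sulfamoyl in place of nitro, the core groups of compound 1 and compound 2, which both carry bromo at this place.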